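The source may hold more compounds than are shown below. What is called first, only, known or untested is meant among the compounds shown, and "the series" means these compounds.

In an assay on HEK293 cells for positive allosteric modulation of metabotropic glutamate receptor 2 (Rattus norvegicus), read by thallium flux, with a stated time of 2.5 min (on this read-out higher numbers stand for larger maximal responses and lower numbers for smaller maximal responses), compound 2 `Cc1cc(C(=O)O)ccc1OCCCCOc1ccc(C(=O)C(C)C)c(O)c1C` gives 76.9%, the lower of the two numbers recorded but within the scatter of compound 1 `CCCC(=O)c1ccc(OCCCCOc2ccc(C(=O)O)cc2C)c(C)c1O`, which gives 79.3%. Compound 3 `CCC(=O)c1ccc(OCCCCOc2ccc(C(=O)O)cc2C)c(C)c1O` differs from compound 2 by hydrogen in place of methyl on a saturated chain carbon bound to a carbonyl carbon and a saturated chain carbon. For the measured compounds named here, the only measured step that bears on this change, a number 2.4 percentage points lower from compound 1 to compound 2 (within the scatter), exchanged isopropyl for propyl on a carbonyl carbon and stayed within the scatter. A similar outcome is expected here, a step of a number 1.1 percentage points higher from compound 2 to compound 3 (within the scatter), none beyond the scatter. Compound 3 is therefore estimated at 78%, with a range from 66% to 90%.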

Compound 3, largest response reached (reported as percent of maximum), in percent of the reference or control that the assay uses: 86.6%
The estimate for compound 3 lay 8.6 percentage points below the measured number, within the range that was stated.
By their numbers in this assay, from the lowest: compounds 2, 1 and 3 (each within the scatter of the next).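

In this assay, the exchange of isopropylcarbonyl for propanoyl comes to a number 9.7 percentage points higher from compound 2 to compound 3 (within the scatter), and hydrogen in place of methyl on a saturated chain carbon, two bonds along the chain from a carbonyl carbon, comes to a number 7.3 percentage points higher from compound 1 to compound 3 (within the scatter). Removing one carbon from this acyl chain, whether branched or unbranched, thus leaves the maximal response within the scatter. Nothing available speaks to a cause for these results. Still open, from the compounds shown here alone, is whether an amine, a cyclopropyl group or a longer chain at this carbonyl carbon would move the response beyond the scatter.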